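Alkyl chain shortening on the shared core

The source may report more compounds than this note shows. Statements on the series, on what has been measured and on what is new or still open speak of the compounds shown alone.

Compounds with the shared core are tested in a functional assay on the whole organism for inhibition, with Spinacia oleracea as the target, read by spectrophotometry, with a stated time of 4 h; a lower number here means a stronger inhibitor, a higher number a weaker inhibitor. Compound 1 `CCCCc1cnc(C(=O)/C=C/c2ccc(O)cc2)cn1` gives 306000 nM in this assay. Compound 2 `CC(C)Cc1cnc(C(=O)/C=C/c2ccc(O)cc2)cn1` gives 235000 nM in this assay, the lower of the two numbers, though the step of a 1.3-fold lower number from compound 1 to compound 2 (0.11 log units; within the scatter) lies within the scatter, so the two compounds are not distinguished.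

Compound 3 `CC(C)c1cnc(C(=O)/C=C/c2ccc(O)cc2)cn1` differs from compound 2 by isopropyl in place of isobutyl on an aromatic carbon. For the measured compounds named here, the only measured step, a 1.3-fold lower number from compound 1 to compound 2 (0.11 log units; within the scatter), also changes the alkyl group on the same aromatic carbon of the core and did not reach beyond the scatter. On that basis no step beyond the scatter is expected in this assay for the change from compound 2 to compound 3, and the estimated step is a 1.1-fold higher number from compound 2 to compound 3 (0.04 log units; within the scatter). For compound 3 the expected value in this assay is 260000 nM, with a range from 120000 nM to 550000 nM.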

Compound 3, half-maximal inhibitory concentration: 315000 nM
The estimate for compound 3 lay 1.2-fold (0.08 log units) below the measured number; the measured number falls inside the stated range.
By their numbers in this assay, from the lowest: compounds 2, 1 and 3 (each within the scatter of the next).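

In this assay the isopropyl group in place of isobutyl on this aromatic carbon gives a 1.3-fold higher number from compound 2 to compound 3 (0.13 log units; within the scatter) and the isopropyl group in place of butyl gives a 1.0-fold higher number from compound 1 to compound 3 (0.01 log units; within the scatter) and so neither step leaves the scatter. With the earlier step, this places butyl, isobutyl and isopropyl at this position within the scatter of one another, so the three compounds show no dependence of the number on the length or branching of these alkyl groups. No supporting measurement accompanies these results to account for this.

Whether any group at this aromatic carbon can move the number beyond the scatter stays open, since only these three alkyl groups are shown. A much longer chain such as octyl, a smaller group such as methyl, or an amine or a carboxylic acid could each test this.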